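Moving a Methyl Along a Carbamate Side Chain

The source may report more compounds than this note shows. Statements on the series, on what has been measured and on what is new or still open speak of the compounds shown alone.

In a functional assay on HEK293 cells for antagonist activity at Voltage-dependent T-type calcium channel subunit alpha-1H (Homo sapiens), read by patch clamp, tested at 1 uM (on this read-out lower numbers stand for less inhibition and higher numbers for more inhibition at the one concentration tested (going by the name of the read-out)), compound 1 `CC(=O)Nc1cccc(S(=O)(=O)N(CC(=O)OC(C)C)c2cccc(Cl)c2)c1` gives 0%, while compound 2 `CC(C)OC(=O)CN(c1cccc(Cl)c1)S(=O)(=O)c1cccc(NC(=O)CN(C)C(=O)OCc2ccccc2)c1` gives 78%, the higher of the two numbers. The step of a number 78 percentage points higher from compound 1 to compound 2 (beyond the scatter) shows that the appended side chain carries the whole effect seen so far. Compound 3 `CC(C)OC(=O)CN(c1cccc(Cl)c1)S(=O)(=O)c1cccc(NC(=O)CCNC(=O)OCc2ccccc2)c1` keeps the same atoms but joins them differently: ((benzyloxycarbonyl)amino)methyl in place of (benzyloxycarbonyl)(methyl)amino on a saturated chain carbon bound to a carbonyl carbon. Within the data shown here, no measured step covers such a rearrangement; the only measured step concerns adding the group, not reshaping it, so a modest shift in this assay is expected, in either direction, likely within the scatter. Compound 3 is therefore estimated at 62%, between 30% and 85%. The expected step is a number 16 percentage points lower from compound 2 to compound 3 (beyond the scatter).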

Compound 3, a percentage reported as inhibition, at one concentration (the size of the read-out at that concentration, not a potency): 73%
Estimate against measurement, compound 3: 11 percentage points below; measured number inside the range.
By their numbers in this assay, from the lowest: compound 1; then compounds 3 and 2 (each within the scatter of the next).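

Swapping (benzyloxycarbonyl)(methyl)amino for ((benzyloxycarbonyl)amino)methyl gives a number 5 percentage points lower from compound 2 to compound 3 (within the scatter) in this assay, so this read-out does not separate the two arrangements of the same atoms, although only the entering group has a hydrogen-bond donor. The large gain from adding a side chain also holds for the new arrangement, with a number 73 percentage points higher from compound 1 to compound 3 (beyond the scatter). Nothing available explains why the two arrangements read alike. Still open, as far as these compounds go, is whether a longer chain, or a free amine in place of the benzyloxycarbonyl group, would keep this inhibition.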